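The source may hold more compounds than are shown below. What is called first, only, known or untested is meant among the compounds shown, and "the series" means these compounds.

Of the compounds shown here, three of a shared core have been tested in a functional assay on DU-145 cells (Homo sapiens) for cytotoxicity, read by trypan blue exclusion, with a stated time of 96 h; on this read-out higher numbers stand for weaker inhibition and lower numbers for stronger inhibition. Compound 1 `COc1cc(OC)c(/C=C/S(=O)(=O)Cc2ccc(OC)c([N+](=O)[O-])c2)c(OC)c1` gives 2500 nM, compound 2 `COc1cc(OC)c(/C=C/S(=O)(=O)Cc2ccc(Cl)c(N)c2)c(OC)c1` gives 10 nM, and compound 3 `COC(=O)C(Nc1cc(CS(=O)(=O)/C=C/c2c(OC)cc(OC)cc2OC)ccc1OC)c1ccc(F)cc1` gives 300 nM. On these numbers compound 3 stands second highest of the three: its value lies closest to that of compound 1, while compound 2 sits far lower and is the strongest inhibitor here.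

Compound 4 `COc1ccc(C(Nc2cc(CS(=O)(=O)/C=C/c3c(OC)cc(OC)cc3OC)ccc2OC)C(=O)O)cc1` has not yet been measured. It differs from compound 3 in one place: carboxy(4-methoxyphenyl)methyl in place of (4-fluorophenyl)(methoxycarbonyl)methyl on a nitrogen on an aromatic ring. Going by the values given here, no measured pair shows a step of this kind, so the direction must be guessed. A modest move toward weaker inhibition is expected, a step of a 3.3-fold higher number from compound 3 to compound 4 (0.52 log units; beyond the scatter). In this assay compound 4 is therefore estimated at 1000 nM, within a range from 200 nM to 5000 nM.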

Compound 4, half-maximal inhibitory concentration: 100 nM
Compound 4: the middle estimate sits 10-fold (1.00 log units) above what was measured, and the stated range ends above it.
By their numbers in this assay, from the lowest: compound 2; then compound 4; then compound 3; then compound 1.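

In this assay, this substituent on a nitrogen on an aromatic ring proves open to change, with a 3.0-fold lower number from compound 3 to compound 4 (0.48 log units; beyond the scatter), a modest step toward stronger inhibition. The step swaps two features at once: methoxycarbonyl becomes carboxy, and 4-fluorophenyl becomes 4-methoxyphenyl. Nothing available explains the gain.

The compounds shown do not reveal which swap carries the step, since neither feature changes alone. A primary amide in place of the carboxy group would show whether the free acid itself is needed.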